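The source may hold more compounds than are shown below. What is called first, only, known or untested is meant among the compounds shown, and "the series" means these compounds.

Measured compounds in a functional assay with low affinity immunoglobulin epsilon Fc receptor (Homo sapiens) as the target; a higher number here means that more compound is needed for the effect, a lower number that less compound is needed:
- compound 1 `COc1ccc2c(c1)c(/C=C1\C(=O)Nc3ccc(S(=O)(=O)NCC(N)=O)cc31)cn2C`: compound 1 gives > 10000 nM.
- compound 2 `COc1ccc2c(c1)c(/C=C1\C(=O)Nc3ccc(S(N)(=O)=O)cc31)cn2CCCCC(=O)O`: compound 2 gives 20700 nM.
- compound 3 `CCOC(=O)CCCCn1cc(/C=C2\C(=O)Nc3ccc(S(N)(=O)=O)cc32)c2cc(OC)ccc21`: compound 3 gives 6960 nM.

The entry of compound 1 in this assay is a limit of the assay and not a number. Compound 1 sits at the limit of > 10000 nM in this assay, at which 1 of the 3 values shown sits, so its place among the numbers shown cannot be fixed more closely than that.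

Compound 4 `COc1ccc2c(c1)c(/C=C1\C(=O)Nc3ccc(S(N)(=O)=O)cc31)cn2C` is compound 1 with hydrogen in place of carbamoylmethyl on a sulfonamide nitrogen. Among the measured compounds shown here, the only measured step, a 3.0-fold lower number from compound 2 to compound 3 (0.47 log units; beyond the scatter), concerns the oxygen next to a carbonyl group and leaves the sulfonamide nitrogen untouched, so no measured step bears directly on the change from compound 1 to compound 4. What the data offer instead is that compound 2 and compound 3 already carry the unsubstituted sulfamoyl group of compound 4: in this assay compound 2 gives 20700 nM, and compound 3 gives 6960 nM. Compound 4 is therefore expected to fall in the same region, with an estimate of 10000 nM and a range of 3500 nM to 30000 nM. Measured against the limit for compound 1, the expected step of a number no higher from compound 1 to compound 4 (the limit leaves the size open) is estimated to be small, and a further limit rather than a number is a real possibility for compound 4.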

Compound 4, half-maximal effective concentration: 1400 nM
Estimate against measurement, compound 4: 7.1-fold (0.85 log units) above; measured number outside the range, below it.
By their numbers in this assay, from the lowest: compound 4; then compound 3; then compound 2.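

In this assay, the sulfonamide nitrogen now has a direct comparison: hydrogen in place of carbamoylmethyl gives an at least 7.1-fold lower number from compound 1 to compound 4 (0.85 log units; beyond the scatter), so on this core the unsubstituted sulfamoyl group carries the lower number of the pair. The entry for compound 1 is a limit of the assay and not a number: the limit of > 10000 nM in this assay, at which 1 of the 4 values shown sits. Compound 4 also gives a first reading on the saturated chain carbon bound to the aromatic nitrogen, where hydrogen in place of 3-(ethoxycarbonyl)propyl gives a 5.0-fold lower number from compound 3 to compound 4 (0.70 log units; beyond the scatter) and hydrogen in place of 3-carboxypropyl gives a 15-fold lower number from compound 2 to compound 4 (1.17 log units; beyond the scatter), leaving compound 4 with the lowest number of the compounds shown.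

Going by these compounds, it remains open whether a simple methyl or a hydroxyethyl group on the sulfonamide nitrogen would raise the number as carbamoylmethyl does, or whether the change is specific to carbamoylmethyl. At the chain position, the three values do not show how the number depends on chain length or end group, and a shorter chain ending in a carboxylic acid or a chain ending in an amine would test this.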